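A few compounds are considered here, and "the series" means these few. Any claim that something is new, unique, unknown or untested is made for them only; others in the source may bear on it.

Compound 1 `COc1ccc(-c2cnc(NC(=O)c3cccnc3)n2C)cc1`: in a toxicity assay on THP-1 cells (Homo sapiens) for inhibition (on this read-out higher numbers stand for lower toxicity in this test and lower numbers for higher toxicity in this test), compound 1 gives > 100000 nM, which is a limit of the assay.
Compound 2 `COc1ccc(-c2cnc(NC(=O)C3CCOCC3)n2C)cc1`: compound 2 gives > 100000 nM, also a limit.
Compound 3 `CCC(=O)Nc1ncc(-c2ccc(OC)cc2)n1C`: compound 3 gives > 100000 nM, again a limit.

Compound 3 thus stands at the limit, and so do the other two measured compounds (the limit of > 100000 nM in this assay, at which 3 of the 3 values shown sit). Compound 4 `COc1ccc(-c2cnc(NC(=O)c3cccc(O)c3)n2C)cc1` differs from compound 3 by 3-hydroxyphenyl in place of ethyl on a carbonyl carbon. The measured steps that touch the same carbonyl carbon are a step that the two limits leave unreadable from compound 1 to compound 3 and a step that the two limits leave unreadable from compound 2 to compound 3, and the third measured step is a step that the two limits leave unreadable from compound 1 to compound 2; all three are unreadable, so they give no direction and no size for the coming step. With every measured value sitting at the limit, the step in this assay is expected to be none beyond the scatter, most likely ending at the limit once more. Compound 4 is therefore estimated at 100000 nM, with a range from 40000 nM to 300000 nM. The estimated step is a number no higher from compound 3 to compound 4 (the limit leaves the size open).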

Compound 4, half-maximal cytotoxic concentration: > 100000 nM
Compound 4: a limit, no number (the forecaster's own chance of this, stated with the estimate: 80%); the middle value lies on the limit itself.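

Compound 4 gives > 100000 nM as a limit of the assay, so its steps from compound 1, compound 2 and compound 3 cannot be read: the limit of > 100000 nM in this assay, at which 4 of the 4 values shown sit.
The compounds shown leave open which group on the carbonyl carbon, if any, would give a number in this assay rather than a limit.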